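This account rests on a few compounds, and the source may have more. Where it says the series, first, only, none or still open, it means among the compounds named here.

Compound 1 `Nc1nc(N2CCN(C(=O)COc3ccc(Cl)cc3)CC2)c2nc(-c3ccc(F)cc3)sc2n1` gives 490 nM in a functional assay on cells (Lymphocyte, Homo sapiens); a lower number here means a stronger inhibitor, a higher number a weaker inhibitor. Compound 2 `Nc1nc(N2CCN(C(=O)COc3ccc(Cl)cc3)CC2)c2nc(CCc3ccc(F)cc3)sc2n1` gives 4400 nM in this assay, and compound 3 `Nc1nc(N2CCN(C(=O)COc3ccc(Cl)cc3)CC2)c2nc(CCOc3ccc(F)cc3)sc2n1` gives 3540 nM, the second highest of the three numbers. Replacing the group on the aromatic carbon of the shared core weakened inhibition in both cases: a 9.0-fold higher number from compound 1 to compound 2 (0.95 log units; beyond the scatter) and a 7.2-fold higher number from compound 1 to compound 3 (0.86 log units; beyond the scatter). Between the other two the difference is small: a 1.2-fold lower number from compound 2 to compound 3 (0.09 log units; within the scatter). Compound 4 `Nc1nc(N2CCN(C(=O)COc3ccc(Cl)cc3)CC2)c2nc(CCCCc3ccc(F)cc3)sc2n1` carries 2-(4-fluorophenyl)ethyl in place of 4-fluorophenoxy on a saturated chain carbon, two bonds along the chain from an aromatic carbon. The step from compound 2 to compound 3 is the one that bears on this exchange, and it stayed within the scatter, so only a small shift is expected in this assay, with a 1.3-fold higher number from compound 3 to compound 4 (0.10 log units; within the scatter) as the expected step. Compound 4 is therefore estimated at 4500 nM, within a range from 1500 nM to 14000 nM.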

Compound 4, half-maximal inhibitory concentration: 920 nM
The estimate for compound 4 lay 4.9-fold (0.69 log units) above the measured number; the measured number lies below the stated range.
By their numbers in this assay, from the lowest: compounds 1 and 4 (each within the scatter of the next); then compounds 3 and 2 (each within the scatter of the next).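

The length of the chain on this aromatic carbon turns out to matter: 4-(4-fluorophenyl)butyl gives a stronger inhibitor than the two shorter chains, with a 3.8-fold lower number from compound 3 to compound 4 (0.59 log units; beyond the scatter) and a 4.8-fold lower number from compound 2 to compound 4 (0.68 log units; beyond the scatter). The earlier compounds shown here suggested that any chain here costs activity, but this one does not, with a 1.9-fold higher number from compound 1 to compound 4 (0.27 log units; within the scatter).

Going by these compounds, whether a longer chain such as 5-(4-fluorophenyl)pentyl, or a butyl chain ending in an amine instead of the 4-fluorophenyl ring, would hold this activity remains open. No supporting measurement bears on this result.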